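The source may hold more compounds than are shown below. What is called first, only, known or untested is meant among the compounds shown, and "the series" means these compounds.

Measured so far:
compound 1 `Cc1ccc(-c2scc3c2CCOC32CCN(Cc3ccccc3)CC2)cc1`: 3.6 nM
compound 2 `COc1ccc(-c2cc3c(s2)C2(CCN(Cc4ccccc4)CC2)OC(OC)C3)cc1`: 56 nM

In an assay on membranes from brain for displacement of a labelled ligand from Sigma non-opioid intracellular receptor 1 (Cavia porcellus), read by scintillation counting, with a stated time of 120 min (on this read-out lower numbers stand for stronger inhibition and higher numbers for weaker inhibition), compound 1 gives 3.6 nM and compound 2 gives 56 nM. Compound 2 stands at the highest of the two numbers; its gap to compound 1 is beyond the scatter, but the two structures differ in more than one place, so the gap is taken only as what the two values show and no single change is assigned to it.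

Compound 3 `COC1Cc2ccsc2C2(CCN(Cc3ccccc3)CC2)O1` has not been measured. Set against compound 2, the change is hydrogen in place of 4-methoxyphenyl on an aromatic carbon. Among the compounds with values here, no measured pair isolates a change of this kind, so the expectation rests on compound 2 alone. For compound 3 a moderate step toward a lower number is expected, a 2.8-fold lower number from compound 2 to compound 3 (0.45 log units; beyond the scatter), with a wide range on either side. The estimate for compound 3 in this assay is 20 nM, expected to fall between 4 nM and 100 nM.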

Compound 3, inhibition constant: 1.9 nM
For compound 3 the middle estimate is 11-fold (1.02 log units) above the measured one; the measured number lies below the stated range.
By their numbers in this assay, from the lowest: compounds 3 and 1 (each within the scatter of the next); then compound 2.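

In this assay, hydrogen in place of 4-methoxyphenyl on this aromatic carbon, next to the ring sulfur, gives a 29-fold lower number from compound 2 to compound 3 (1.47 log units; beyond the scatter). The step is large, which shows that a low number in this series does not depend on having 4-methoxyphenyl at this position: with the other parts of compound 2 kept, the bare aromatic carbon is clearly preferred. Nothing measured here accounts for the size of the step.

The compounds shown compare only 4-methoxyphenyl and hydrogen at this carbon, so it remains open how the number responds to size at this position, for instance with a methyl, a chlorine atom or an unsubstituted phenyl. From the compounds shown here alone, it is also open whether the methoxy on the phenyl ring contributes to the step, which a hydroxy or a fluorine atom in its place would begin to test.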